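The compounds below may be only part of what the source reports. "The series", "measured", "known", "first", "only" and "open" are said of these compounds alone.

For the measured compounds named here, compound 2 `COc1ccc(-n2c(-c3ccccc3)cc3c2CCCC3)cc1C(=O)O` stands lowest of the two numbers measured so far in a functional assay on the whole organism (strain Wistar) for inhibition, with Rattus norvegicus as the target, read by paw edema, with stated times of 30 min and 3 h, at a dose of 200 mg/kg by the oral route (a lower number here means less inhibition, a higher number more inhibition at the dose given (going by the name of the read-out)), where compound 2 gives 40%. Its nearest neighbour is compound 1 `CC(=O)Oc1ccc(-n2c(-c3ccccc3)cc3c2CCCC3)cc1C(=O)O`, which in this assay gives 50%; the step of a number 10 percentage points lower from compound 1 to compound 2 (within the scatter) is within the scatter, so these two numbers cannot be told apart. Compound 3 `O=C(O)c1cc(-n2c(-c3ccccc3)cc3c2CCCC3)ccc1Cl` is the next in line, not yet measured; it differs from compound 2 in one place, (chloro in place of methoxy on an aromatic carbon). Going by the values given here, the one measured step is the only guide, and it also changed the group on the ring carbon in question, from acetyl to methyl on the oxygen, with the step of a number 10 percentage points lower from compound 1 to compound 2 (within the scatter) staying within the scatter. Swapping the whole methoxy for chloro is a larger change, but nothing measured points to a direction, so in this assay compound 3 is expected to sit near compound 2, with a step of a number 2 percentage points higher from compound 2 to compound 3 (within the scatter). The estimate for compound 3 in this assay is 42%, expected to fall between 22% and 62%.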

Compound 3, a percentage reported as inhibition, in the whole organism at one dose (the size of the read-out at that dose, not a potency): 40%
Compound 3: middle estimate off by 2 percentage points, on the high side, and the stated range covers the measured number.
By their numbers in this assay, from the lowest: compounds 2, 3 and 1 (each within the scatter of the next).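

Chloro now joins methoxy and acetoxy on this aromatic carbon, which is ortho to a carboxy group and para to a large group. In this assay the swap of methoxy for chloro gives no change at the digits printed from compound 2 to compound 3 (within the scatter) and the swap of acetoxy for chloro gives a number 10 percentage points lower from compound 1 to compound 3 (within the scatter), so the three groups cannot be told apart at this one dose. An oxygen attached to the ring at this carbon, present in compound 1 and compound 2 but absent from compound 3, is therefore not needed for this level of inhibition in these compounds.

From the compounds shown here alone, whether an amine, a hydroxy group or a longer chain at this carbon would move the number beyond the scatter stays open. The compounds shown also leave open why these three groups read alike, as no measurement at hand bears on that.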